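The compounds below may be only part of what the source reports. "The series", "measured", "known", "first", "only" and "open" are said of these compounds alone.

Measured so far:
compound 1, `O=C(CCCCCc1ccccc1)OCC1COCCOCCOCCOCCOCCO1`, in a functional assay on SW1573 cells (Homo sapiens) for inhibition, read by sulforhodamine B assay, with a stated time of 48 h; on this read-out higher numbers stand for weaker inhibition of growth and lower numbers for stronger inhibition of growth: 78000 nM
compound 2, `O=C(CCCCOc1ccccc1)OCC1COCCOCCOCCOCCOCCO1`: > 100000 nM

Compound 1 and compound 2 share the same core and differ only in the aromatic tail. In this assay compound 1 gives 78000 nM. For compound 2 only a limit is known in this assay, > 100000 nM. The one measured step, an at least 1.2-fold higher number from compound 1 to compound 2 (0.10 log units; that floor lies within the scatter), is itself bounded by the limit of > 100000 nM in this assay, at which 1 of the 2 values shown sits, so compound 2 stands at the weak edge of the numbers shown, with no reading of its own.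

Compound 3, `O=C(CCCc1cc2ccccc2[nH]1)OCC1COCCOCCOCCOCCOCCO1`, takes the change (1H-indol-2-yl in place of phenoxymethyl on a saturated chain carbon, three bonds along the chain from a carbonyl carbon). Within the data shown here, no measured step touches an indolyl tail, and the only step available, an at least 1.2-fold higher number from compound 1 to compound 2 (0.10 log units; that floor lies within the scatter), reaches no further than the scatter. There is therefore no ground to expect a move beyond the scatter in either direction in this assay, and a second limit is as likely as a number. Compound 3 is accordingly expected to give about 90000 nM, within 30000 nM to 250000 nM, which amounts to an expected step of an at least 1.1-fold lower number from compound 2 to compound 3 (0.04 log units; that floor lies within the scatter).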

Compound 3, concentration for 50% growth inhibition: > 100000 nM
Compound 3: no number, only a limit; the forecaster's own chance of this, stated with the estimate: 50%; middle value at least 1.1-fold (0.04 log units) away from the limit.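

In this assay compound 3 gives only a limit, > 100000 nM. Among these compounds, a tail carrying 1H-indol-2-yl at this place, with its five-membered aromatic ring and its hydrogen-bond donor, therefore gives no reading of its own, and the same holds for the phenoxymethyl tail it replaces: the limit of > 100000 nM in this assay, at which 2 of the 3 values shown sit. The one step that can be read is an at least 1.2-fold higher number from compound 1 to compound 3 (0.10 log units; that floor lies within the scatter), while the step joining the two limits cannot be read.

The compounds shown leave open how far compound 2 and compound 3 lie from each other, and whether the two tails differ at all on this read-out. Also open, as far as these compounds go, is whether an amine or a carboxylic acid on the chain, or a longer chain ending in 1H-indol-2-yl, would give a number rather than a limit.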